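Methoxy replaced by chloro on the pyrazoline aryl ring

The compounds below may be only part of what the source reports. "The series", "measured", "known", "first", "only" and "open" are said of these compounds alone.

Measured compounds:
compound 1 `COc1ccc(C2=NN(C(=O)c3ccc(C)nc3Cl)C(c3ccc(OC)cc3)C2)cc1`, in a functional assay on WM 266-4 cells (Homo sapiens) for antiproliferative activity, read by MTT assay, with a stated time of 24 h (a higher number here means a weaker inhibitor of growth, a lower number a stronger inhibitor of growth), compound 1 gives 5740 nM
compound 2 `COc1ccc(C2=NN(C(=O)c3ccc(C)nc3Cl)C(c3ccc(Cl)cc3)C2)cc1`, in this assay compound 2 gives 1440 nM
compound 3 `COc1ccc(C2=NN(C(=O)c3cncc(Br)c3)C(c3ccc(OCc4ccccc4)cc3)C2)cc1`, in this assay compound 3 gives 6240 nM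

Compound 4 `O=C(c1cncc(Br)c1)N1N=C(c2ccc(Cl)cc2)CC1c1ccc(OCc2ccccc2)cc1` is not yet measured. The change from compound 1 to compound 2, (chloro in place of methoxy on an aromatic carbon), gave a 4.0-fold lower number from compound 1 to compound 2 (0.60 log units; beyond the scatter) in this assay. The change from compound 3 to compound 4, (chloro in place of methoxy on an aromatic carbon), is the same change, with the same place description; the difference between the two cores of compound 1 and compound 3 is not broken down here. Compound 3 and compound 1 lie within the scatter of each other, and compound 3 stands highest of the three numbers. For compound 4, a step of a 3.5-fold lower number from compound 3 to compound 4 (0.54 log units; beyond the scatter) in this assay is expected, resting on the step from compound 1 to compound 2, a 4.0-fold lower number from compound 1 to compound 2 (0.60 log units; beyond the scatter), and on the value of compound 3, 6240 nM. Compound 4 is therefore estimated at 1800 nM in this assay, with a range of 700 nM to 5000 nM.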

Compound 4, concentration for 50% growth inhibition: 8130 nM
Compound 4: middle estimate off by 4.5-fold (0.65 log units), on the low side; the whole stated range lies below it.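

In this assay, chloro in place of methoxy on the core of compound 3 gives a 1.3-fold higher number from compound 3 to compound 4 (0.11 log units; within the scatter), so the drop in the number seen on the core of compound 1 does not reappear here. The same change therefore behaves differently on the two cores: the same change on two cores in this assay, a 4.0-fold lower number (0.60 log units; beyond the scatter) from compound 1 to compound 2 and a 1.3-fold higher number (0.11 log units; within the scatter) from compound 3 to compound 4, 5.2-fold (0.72 log units) apart, beyond the scatter of two such steps

For the compounds shown here, this shows that the step from compound 1 to compound 2 cannot be carried over to the core of compound 3, but with only two pairs it gives no rule for the series and does not show which difference between the cores matters. It remains open which part of the core of compound 3 accounts for the difference. Also open, going by these compounds, is how fluoro, an amine or a carboxylic acid in the same place would behave on either core.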